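The source may hold more compounds than are shown below. What is called first, only, known or untested is meant among the compounds shown, and "the series" means these compounds.

Measured so far:
- compound 1, `C=C1CCC[C@H]2[C@](C)(CCC(C)=O)[C@@H](C)CC[C@]12C`: in a functional assay on HT-29 cells (Homo sapiens) for inhibition (on this read-out higher numbers stand for weaker inhibition of growth and lower numbers for stronger inhibition of growth), compound 1 gives > 15000 nM; this is a limit of the assay, not a number.
- compound 2, `CC1=C(CC/C(C)=C/CC[C@@]2(C)CC[C@@H]([C@H](C)C(=O)O)OO2)C(C)(C)CCC1`: in this assay compound 2 gives > 100000 nM; this is a limit of the assay, not a number.

Where compound 2 stands: its value is only a limit, and the other value shown is a limit as well, so no ordering between compound 2 and compound 1 can be read from these numbers. For the measured compounds named here, no step between two measured compounds is recorded.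

The next compound is compound 3, `CC1=C(CC/C(C)=C/CC[C@@]2(C)CC[C@H]([C@H](C)C(=O)O)OO2)C(C)(C)CCC1`, not yet measured in this assay. Compared with compound 2 it changes as follows: the two compounds have the same atoms and bonds and differ only in configuration as drawn: 1 of 4 stereo elements differ; a stereocentre at a saturated ring carbon is drawn S in compound 2 and R in compound 3. Going by the values given here, a change in configuration only, with no atom leaving or entering, gives no measured step to lean on here. The step from compound 2 to compound 3 is expected to be small, an at least 1.4-fold lower number from compound 2 to compound 3 (0.15 log units; that floor lies within the scatter), with no direction preferred, and a further limit is the likeliest outcome. Compound 3 is therefore expected to give about 70000 nM, within the range 10000 nM to 300000 nM.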

Compound 3, concentration for 50% growth inhibition: > 5000 nM
Compound 3 ended at the assay's limit (the forecaster's own chance of this, stated with the estimate: 70%); the middle value is on the limit's open side.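

In this assay compound 2 gives > 100000 nM, a limit of the assay. Compound 3 gives > 5000 nM, also a limit, and no step can be read between the two. The compounds shown leave open whether the configuration at this saturated ring carbon affects growth inhibition at all.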